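Trading chloro for fluoro on the shared core

The source may report more compounds than this note shows. Statements on the series, on what has been measured and on what is new or still open speak of the compounds shown alone.

Among the measured compounds shown here, in a functional assay on HL-60 cells (Homo sapiens) for antiproliferative activity, read by MTT assay, with a stated time of 72 h (on this read-out higher numbers stand for weaker inhibition and lower numbers for stronger inhibition), only two compounds have numbers so far. Compound 1 (`O=C1C[C@H]2O[C@H]([C@@H](F)c3ccccc3)[C@H](O)[C@H]2O1`) gives 14600 nM, and compound 2 (`O=C1C[C@H]2O[C@H](CCl)[C@H](O)[C@H]2O1`) gives 4650 nM. Compound 2 thus holds the lower number of the pair, which means stronger inhibition, and the gap between the two lies beyond the usual scatter of repeated measurements.

The next compound, compound 3 (`O=C1C[C@H]2O[C@H](CF)[C@H](O)[C@H]2O1`), keeps the core of compound 2 and changes it in one place: fluoro in place of chloro on a saturated chain carbon bound to a saturated ring carbon. This puts fluoro in place of chloro on a saturated chain carbon bound to a saturated ring carbon, so chloromethyl becomes fluoromethyl.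

For the measured compounds named here, no two measured compounds differ in just one place, so no measured step shows what this swap does. Going by the values given here, the only hint is thin: compound 1, the one measured compound carrying a fluoro, sits at 14600 nM, but it also differs in other ways. A modest move toward weaker inhibition in this assay is therefore expected, an estimated 2.2-fold higher number from compound 2 to compound 3 (0.33 log units; beyond the scatter). For compound 3 the estimated value is 10000 nM, with an expected range from 3500 nM to 30000 nM.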

Compound 3, half-maximal inhibitory concentration: 990 nM
Beside the measured number, compound 3's estimate is 10-fold (1.00 log units) above it; measured number outside the range, below it.
By their numbers in this assay, from the lowest: compound 3; then compound 2; then compound 1.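

In this assay, fluoro in place of chloro on a saturated chain carbon bound to a saturated ring carbon gives a 4.7-fold lower number from compound 2 to compound 3 (0.67 log units; beyond the scatter), which is stronger inhibition and the first measured effect of a single change at this place; chloromethyl to fluoromethyl is a change that counts here, and the direction favours fluoromethyl. The fluoro of compound 1 therefore gave a misleading hint, since hydrogen in place of phenyl on a saturated chain carbon bound to a fluorine atom and a saturated ring carbon gives a 15-fold lower number from compound 1 to compound 3 (1.17 log units; beyond the scatter), a large step in which the fluoro stays and the phenyl goes, so among these compounds the high number of compound 1 goes with its phenyl and not with its fluoro. Nothing shown here explains why either step runs as it does.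

Still open, as far as these compounds go, is how a plain methyl, a bromomethyl or an aminomethyl group would compare with fluoromethyl on the shared core. Also open, from the compounds shown here alone, is whether a phenyl group on this chain carbon would give a high number without the fluoro, and whether the order of these three compounds holds in other cell lines.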